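A few compounds are considered here, and "the series" means these few. Any claim that something is new, unique, unknown or untested is made for them only; others in the source may bear on it.

Measured compounds:
compound 1 `CCCCN(CCC)c1nc(C)nc2c(-c3c(C)cc(N(C)C)nc3C)c(C)nn12`, 12.8 nM
compound 2 `CCCCN(CC)c1nc(C)nc2c(-c3ccc(OC)nc3C)c(C)nn12`, 4.9 nM

In an assay on cell membranes for displacement of a labelled ligand from corticotropin-releasing factor receptor 1 (Rattus norvegicus) (a higher number here means a weaker inhibitor, a lower number a stronger inhibitor), compound 2 gives 4.9 nM, the lower of the two numbers; compound 1 gives 12.8 nM, a gap beyond the usual scatter. Compound 3 `CCCCC(C)Nc1nc(C)nc2c(-c3ccc(OC)nc3C)c(C)nn12` has not yet been measured. It differs from compound 2 in one place: (1-methylpentyl)amino in place of butyl(ethyl)amino on an aromatic carbon. Going by the values given here, no step between measured compounds shows the effect of such a rearrangement, so only a small shift, in either direction, is anticipated. The expected step is a 1.6-fold higher number from compound 2 to compound 3 (0.21 log units; within the scatter), within the scatter of repeat measurements. Compound 3 is estimated to give 8 nM, with a likely range from 2.5 nM to 25 nM.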

Compound 3, half-maximal inhibitory concentration: 5.1 nM
For compound 3 the middle estimate is 1.6-fold (0.20 log units) above the measured one; measured number inside the range.
By their numbers in this assay, from the lowest: compounds 2 and 3 (each within the scatter of the next); then compound 1.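

In this assay, putting (1-methylpentyl)amino in place of butyl(ethyl)amino on the aromatic carbon between two ring nitrogen atoms gives a 1.0-fold higher number from compound 2 to compound 3 (0.02 log units; within the scatter) and so leaves the reading within the scatter. At this position, the same atoms joined differently, with a hydrogen-bond donor that butyl(ethyl)amino lacks, therefore give a comparable number on this core. The data offer no explanation for this match. As far as these compounds go, what remains open is whether a shorter chain such as propylamino, or a ring amine such as morpholine, would be accepted here as well.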